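The source may report more compounds than this note shows. Statements on the series, on what has been measured and on what is new or still open speak of the compounds shown alone.

Working notes on the series. In a functional assay on PC-3 cells (Homo sapiens), with a stated time of 24 h, tested at 10 uM (a higher number here means more inhibition at the concentration tested (going by the name of the read-out), a lower number less inhibition), compound 1 `O=C(Nc1ccc(Cl)cc1)C1CCCN(C(=O)c2cccc(-c3ccco3)c2)C1` gives 70%. In this assay compound 2 `Cc1nc(-c2cccc(NC(=O)C3CCCN(C(=O)c4cc(C(F)(F)F)cc(C(F)(F)F)c4)C3)c2)cs1` gives 42%, the lower of the two numbers and separated from compound 1 by a gap beyond the usual scatter. Compound 3 `O=C(Nc1cccc(Oc2ccccc2)c1)C1CCCN(C(=O)c2cc(C(F)(F)F)cc(C(F)(F)F)c2)C1` has not yet been measured in this assay. The change from compound 2 to compound 3 is phenoxy in place of 2-methyl-1,3-thiazol-4-yl on an aromatic carbon; the remainder of the shared core is kept. For the measured compounds named here, no pair of measured compounds that differ in one place is available, so the step cannot be anchored on a measured step of the same kind. The expectation is therefore a small step, not clearly beyond the scatter in either direction, resting on the reading of compound 2 42%. The expected step is a number 8 percentage points higher from compound 2 to compound 3 (within the scatter). Compound 3 is estimated at 50% in this assay, with a range of 25% to 75%.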

Compound 3, a percentage reported as inhibition, at one concentration (the size of the read-out at that concentration, not a potency): < 30%
Compound 3 ended at the assay's limit; the forecaster's own chance of this, stated with the estimate: 0%; middle value at least 20 percentage points away from the limit.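

For the compounds shown here, this is the first measured step at this aromatic carbon: with phenoxy in place of 2-methyl-1,3-thiazol-4-yl and the rest of the shared core kept, the change gives a number at least 12 percentage points lower from compound 2 to compound 3 (beyond the scatter), so the reading in this assay depends on which group sits here. Compound 3 gives < 30%, which is a limit of the assay and not a number. The step is therefore a bound, and its full size cannot be read: the limit of < 30% in this assay, at which 1 of the 3 values shown sits.

Compound 1 differs from compound 2 and compound 3 in more than one place, so it gives no reading of this position. The compounds shown leave open whether the drop follows from the oxygen link or from the six-membered ring, and how an amine or a carboxylic acid on the same carbon would read.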